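The source may report more compounds than this note shows. Statements on the series, on what has been measured and on what is new or still open speak of the compounds shown alone.

In an in vitro ADME assay on microsomes (Mus musculus) for metabolic stability (a higher number here means that the compound lasts longer, a lower number that the compound disappears faster), compound 1 (`CNC(=O)Nc1ccc(-c2nc(N3CC4CCC(C3)O4)c3cnn(C(C)C)c3n2)cc1`) gives > 0.5 h, which is a limit and not a number. Compound 2 (`O=C(Nc1ccncc1)Nc1ccc(-c2nc(N3CC4CCC(C3)O4)c3cnn(C4CCC5(CC4)OCCO5)c3n2)cc1`) gives > 0.5 h, which is also a limit. Compound 1 therefore stands with the rest of the series at the limit of > 0.5 h in this assay, at which 2 of the 2 values shown sit. Among the compounds with values here, no measured step exists between compounds, so the series offers no size for any structural change.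

The next compound is compound 3 (`CNC(=O)Nc1ccc(-c2nc(N3CC4CCC(C3)O4)c3cnn([C@H]4CC[C@H](OC)CC4)c3n2)cc1`), in which 4-methoxycyclohexyl takes the place of isopropyl on an aromatic nitrogen: 4-methoxycyclohexyl in place of isopropyl on an aromatic nitrogen. The rest of compound 1 is kept.

Within the data shown here, with no measured step to draw on, no change beyond the usual scatter is expected in this assay, in either direction, and another limit reading is quite likely. The expected size of the change is a number no higher from compound 1 to compound 3 (the limit leaves the size open). That expectation rests only on compound 1 at > 0.5 h, a limit. For compound 3 the estimated half-life is 0.5 h, with an expected range from 0.2 h to 1 h.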

Compound 3, half-life: > 0.5 h
Compound 3 ended at the assay's limit; the forecaster's own chance of this, stated with the estimate: 60%; the middle value lies on the limit itself.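

In this assay, no step can be read from compound 1 to compound 3, because both compounds give limits and not numbers: the limit of > 0.5 h in this assay, at which 3 of the 3 values shown sit.

The compounds shown leave open the actual half-life of each compound and whether 4-methoxycyclohexyl in place of isopropyl on an aromatic nitrogen shifts it at all.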